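The source may report more compounds than this note shows. Statements on the series, on what has been measured and on what is new or still open speak of the compounds shown alone.

Measured so far in a functional assay on ECa-109 cells for inhibition, with ECa-109 cell line (Homo sapiens) as the target, read by sulforhodamine B assay; a lower number here means a stronger inhibitor, a higher number a weaker inhibitor:
- compound 1 `O=C1C=C(NCc2ccccc2)C(=O)c2c1nc1n2[C@H]2OC[C@@H](O)[C@H]2OC1` gives > 8000 nM (a limit of the assay, not a number)
- compound 2 `O=C1C=C(Nc2ccc(Br)cc2)C(=O)c2c1nc1n2[C@H]2OC[C@@H](O)[C@H]2OC1` gives 2850 nM
- compound 3 `Cc1ccc(NC2=CC(=O)c3nc4n(c3C2=O)[C@H]2OC[C@@H](O)[C@H]2OC4)cc1` gives 3480 nM

Among the compounds with values here, compound 3 cannot be separated from the only other exact number: a 1.2-fold higher number from compound 2 to compound 3 (0.09 log units; within the scatter), a step within the scatter. Next comes compound 4 `O=C1C=C(N2CCCCC2)C(=O)c2c1nc1n2[C@H]2OC[C@@H](O)[C@H]2OC1`, with piperidin-1-yl in place of (4-methylphenyl)amino on a double-bonded ring carbon.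

The closest evidence comes from two changes on the amine nitrogen: an at least 2.8-fold lower number from compound 1 to compound 2 (0.44 log units; beyond the scatter) and an at least 2.2-fold lower number from compound 1 to compound 3 (0.36 log units; beyond the scatter). Both are at least modest and beyond the scatter. Neither tests a piperidin-1-yl group, so they guide the estimate only loosely. The ceiling also matters here: the limit of > 8000 nM in this assay, at which 1 of the 3 values shown sits.

A modest move toward a higher number, meaning weaker inhibition, is expected in this assay: a 1.6-fold higher number from compound 3 to compound 4 (0.20 log units; within the scatter). The expected value for compound 4 is 5500 nM, with an estimated range from 2000 nM to 12000 nM.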

Compound 4, half-maximal inhibitory concentration: > 8000 nM
Compound 4 was reported as a limit (the forecaster's own chance of this, stated with the estimate: 35%); middle value at least 1.4-fold (0.16 log units) away from the limit.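

Replacing the arylamino groups with piperidin-1-yl on the double-bonded ring carbon weakens inhibition in this assay, beyond the scatter: an at least 2.2-fold higher number from compound 3 to compound 4 (0.36 log units; beyond the scatter) and an at least 2.8-fold higher number from compound 2 to compound 4 (0.44 log units; beyond the scatter). The value of compound 4, > 8000 nM, is a limit of the assay and not a number. Compound 1, with benzylamino, shares this ceiling with compound 4, and the step between them cannot be read: the limit of > 8000 nM in this assay, at which 2 of the 4 values shown sit.

Piperidin-1-yl differs from (4-methylphenyl)amino in both its hydrogen-bond donor count and its ring type, and the compounds shown do not separate these two differences. A cyclohexylamino group, with a non-aromatic ring and the amine hydrogen kept, would test whether the hydrogen or the aromatic ring matters here.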